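This account rests on a few compounds, and the source may have more. Where it says the series, first, only, none or still open, it means among the compounds named here.

Measured in a functional assay on COR-L23 cells (Homo sapiens) for antiproliferative activity, read by CellTiter-Glo, with a stated time of 4 days; on this read-out higher numbers stand for weaker inhibition and lower numbers for stronger inhibition:

Compound 1 `O=C(CCc1cccnc1)Nc1ccc(CN2C(=O)c3ccccc3C2=O)cc1`: > 10000 nM, a limit.
Compound 2 `CCC(=O)N[C@@H](C)c1ccc(NC(=O)NCc2cccnc2)cc1`: 1330 nM.
Compound 3 `CCC(=O)NCc1ccc(NC(=O)[C@H]2C[C@@H]2c2cccnc2)cc1`: > 2500 nM, a limit.

Compound 2 is the only one of the three with a number. Compound 3 has no number on this read-out. Its entry, > 2500 nM, is a limit.

The next compound to be measured is compound 4 `CCC(=O)NC(C)(C)c1ccc(NC(=O)[C@H]2C[C@@H]2c2cccnc2)cc1`, which differs from compound 3 in one place: a group of 8 heavy atoms (6 carbon, 1 nitrogen, 1 oxygen; no ring) in place of a group of 6 heavy atoms (4 carbon, 1 nitrogen, 1 oxygen; no ring), on an aromatic carbon. The (propanoylamino)methyl group leaves, and the group that enters has no common name and no ring. The change sits on an aromatic carbon of a six-membered aromatic ring of carbon only, para to a large group.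

Among the compounds with values here, no pair of measured compounds differs by a single change, so the size of this step cannot be read from earlier data. In this assay, no step beyond the scatter is expected in either direction, and a second limit for compound 4 would not be surprising. This expectation rests on compound 3 and its limit of > 2500 nM, and the range is kept wide to take in a value near that of compound 2. The expected change is a step that the limit leaves unreadable from compound 3 to compound 4. For compound 4 the estimated value is 3000 nM, with an expected range of 800 nM to 10000 nM.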

Compound 4, half-maximal inhibitory concentration: 2310 nM
For compound 4 the middle estimate is 1.3-fold (0.11 log units) above the measured one; low and high end bracket the measured number.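

In this assay compound 4 gives a measured number, 2310 nM, so this position, on an aromatic carbon para to a large group, now has a readable value with this amide-bearing side chain. The entry of compound 3, > 2500 nM, is a limit. The exchange of the (propanoylamino)methyl group for the larger group without a common name can therefore be stated only as an at least 1.0-fold lower number from compound 3 to compound 4 (0.03 log units; that floor lies within the scatter), and its true size stays unread.

Open, as far as these compounds go, is how a free amine or a carboxylic acid on this aromatic carbon would read in this assay, in place of the amide-bearing side chain of compound 4. Also open, from the compounds shown here alone, is whether the read-out follows the size of the group at this position at all, and a longer acyl chain in place of the propanoyl part of compound 4 would be one test of that.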